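The source may hold more compounds than are shown below. What is called first, only, known or untested is meant among the compounds shown, and "the series" means these compounds.

Compound 1 `Cc1cc(-c2nc3c(F)cccc3s2)ccc1N`: 1700 nM
Compound 2 `Cc1cc(-c2nc3cc(F)c(F)cc3s2)ccc1N`: > 100000 nM
Compound 3 `Nc1ccc(-c2nc3cc(F)ccc3s2)cc1Br`: 50 nM

All three compounds were tested in a functional assay on OVCAR-5 cells (Homo sapiens) for inhibition; a higher number here means a weaker inhibitor of growth, a lower number a stronger inhibitor of growth. Compound 1 gives 1700 nM, the higher of the two actual numbers, while compound 3 gives 50 nM, a gap well beyond the scatter. Compound 2 gives > 100000 nM, which is a limit of the assay and not a number.

The next compound, compound 4 `Cc1cc(-c2nc3ccccc3s2)ccc1N`, has not yet been measured in this assay. It departs from compound 1 by a single change, hydrogen in place of fluoro on an aromatic carbon. For the measured compounds named here, no measured pair isolates this change, so the expectation is loose. Compound 3 at 50 nM shows that numbers far lower than that of compound 1 occur among these compounds, so a downward move beyond the scatter is expected. The expected move is an 8.5-fold lower number from compound 1 to compound 4 (0.93 log units; beyond the scatter). For compound 4 the estimated value is 200 nM, with an expected range from 10 nM to 3000 nM.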

Compound 4, concentration for 50% growth inhibition: 1900 nM
The estimate for compound 4 lay 9.5-fold (0.98 log units) below the measured number; the range from low to high includes it.
By their numbers in this assay, from the lowest: compound 3; then compounds 1 and 4 (each within the scatter of the next). At a limit, above all of these: compound 2.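

Hydrogen in place of fluoro on this aromatic carbon, ortho to a fused ring and meta to a fused ring, gives the first one-place comparison among these compounds. In this assay, the step is a 1.1-fold higher number from compound 1 to compound 4 (0.05 log units; within the scatter). At this position, the fluoro therefore makes no difference beyond the scatter on the core of compound 1, and the large downward move expected for this change does not appear. The limit reached by another compound does not bear on this pair, and nothing shown gives a cause for this result.

The compounds shown leave open what a chloro group, a methoxy group or an amine on this same carbon would give. As far as these compounds go, it also remains open whether this change would stay equally flat on the core of compound 3.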